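One Fluorine Fewer: From Compound 3 to Compound 4

The source may hold more compounds than are shown below. What is called first, only, known or untested is meant among the compounds shown, and "the series" means these compounds.

Three compounds have been measured in a functional assay on THP-1 cells (Homo sapiens) for inhibition; a higher number here means a weaker inhibitor, a lower number a stronger inhibitor:

Compound 1 `O=C1NC(=O)/C(=C/c2ccc(C(=O)NC[C@@H]3C[C@@H](OCc4ccccc4-c4ccccc4)CN3C(=O)c3ccc(C(=O)c4ccccc4)cc3)cc2)S1`: 5500 nM
Compound 2 `CC(C)Cc1cccc(Br)c1O[C@@H]1C[C@@H](CNC(=O)c2ccc(/C=C3\SC(=O)NC3=O)cc2)N(C(=O)c2ccccc2C(=O)c2ccc(F)cc2F)C1`: 220 nM
Compound 3 `O=C1NC(=O)/C(=C/c2ccc(C(=O)NC[C@@H]3C[C@@H](OCc4ccccc4-c4ccccc4)CN3C(=O)c3ccccc3C(=O)c3ccc(F)cc3F)cc2)S1`: 230 nM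

Compound 3 holds the second highest of the three numbers. Its nearest neighbour is compound 2, whose value lies within the scatter of that of compound 3, so no order between them can be read. Compound 1 sits far above both, beyond the scatter.

Compound 4 `O=C1NC(=O)/C(=C/c2ccc(C(=O)NC[C@@H]3C[C@@H](OCc4ccccc4-c4ccccc4)CN3C(=O)c3ccccc3C(=O)c3ccc(F)cc3)cc2)S1` differs from compound 3 in one place: hydrogen in place of fluoro on an aromatic carbon. For the measured compounds named here, no measured pair here shows this change on its own, so nothing tells how large a step it brings. The author expects a step of modest size, a 1.3-fold higher number from compound 3 to compound 4 (0.12 log units; within the scatter), probably not beyond the scatter. The value of compound 4 in this assay is estimated at 300 nM, with a range from 120 nM to 800 nM.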

Compound 4, half-maximal inhibitory concentration: 320 nM
The estimate for compound 4 lay 1.1-fold (0.03 log units) below the measured number; the measured number falls inside the stated range.
By their numbers in this assay, from the lowest: compounds 2, 3 and 4 (each within the scatter of the next); then compound 1.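

In this assay, for the compounds shown here, the change from 2,4-difluorophenyl to 4-fluorophenyl gives a 1.4-fold higher number from compound 3 to compound 4 (0.14 log units; within the scatter) and so offers the first direct reading of this position, ortho to a large group. In this single pair, the fluoro can give way to hydrogen without a step beyond the scatter. No measurement given here accounts for this result.

On these data alone, whether a methoxy group, a chlorine atom or an amine at this position would read the same stays open. So does the part played by the remaining fluoro of the 4-fluorophenyl group.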